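Thiophene for Fluorophenyl on a Sulfonamide: an Expectation

This account rests on a few compounds, and the source may have more. Where it says the series, first, only, none or still open, it means among the compounds named here.

Compound 1 `O=S(=O)(Nc1ccc(-c2nc3ccccc3o2)cc1)c1cccc(F)c1` gives > 63000 nM in an assay on isolated protein for inhibition of malate dehydrogenase, mitochondrial (Sus scrofa), with stated times of 45 min and 30 min (a lower number here means a stronger inhibitor, a higher number a weaker inhibitor), which is a limit of the assay rather than a number.
Compound 2 `O=S(=O)(Nc1ccc(-c2nc3ccccc3o2)cc1)c1ccc(Cl)c(C(F)(F)F)c1` gives > 63000 nM in this assay, again a limit.
Compound 3 `O=S(=O)(Nc1ccc2oc(-c3ccccc3)nc2c1)c1ccc(Cl)cc1` gives > 63000 nM in this assay, again a limit.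

On the numbers shown, compound 1 therefore stands at a limit, and so do the other two measured compounds, as the limit of > 63000 nM in this assay, at which 3 of the 3 values shown sit, records. Going by the values given here, no two measured compounds differ in only one place, so there is no measured step whose size could guide an expectation.

Compound 4 `O=S(=O)(Nc1ccc(-c2nc3ccccc3o2)cc1)c1cccs1` is compound 1 with thiophen-2-yl in place of 3-fluorophenyl on a sulfonyl sulfur. Among the compounds with values here, since every value so far is a limit, there is no basis for expecting a step in either direction beyond the usual scatter. Compound 4 is estimated to give 100000 nM in this assay, within a range from 30000 nM to 400000 nM, and most probably to be reported only as a limit once more. The expected step is a step that the limit leaves unreadable from compound 1 to compound 4, which is none beyond the scatter.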

Compound 4, half-maximal inhibitory concentration: > 63000 nM
Compound 4: only a limit was reported (the forecaster's own chance of this, stated with the estimate: 90%); the middle value lies beyond the limit too.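

Going by these compounds alone, compound 1 and compound 4 both stand only at a limit in this assay, so no step between them can be read. The compounds shown leave open whether any structure of this kind gives a true number, and all they offer is this: the limit of > 63000 nM in this assay, at which 4 of the 4 values shown sit.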